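A Longer Chain on the Phenyl Ring of a Triazole Series

This account rests on a few compounds, and the source may have more. Where it says the series, first, only, none or still open, it means among the compounds named here.

Of the compounds shown here, three sharing one core have been measured in a functional assay on HeLa cells (Homo sapiens) for antiproliferative activity, read by MTT assay, with a stated time of 72 h; a higher number here means a weaker inhibitor, a lower number a stronger inhibitor. Compound 1 `O=C1O/C(=C\Cn2cc(-c3ccc(Br)cc3)nn2)C(OCc2ccccc2)=C1OCc1ccccc1` gives 24300 nM in this assay, compound 2 `Cc1ccc(-c2cn(C/C=C3\OC(=O)C(OCc4ccccc4)=C3OCc3ccccc3)nn2)cc1` gives 7480 nM, and compound 3 `O=C1O/C(=C\Cn2cc(-c3cc(F)cc(F)c3)nn2)C(OCc2ccccc2)=C1OCc1ccccc1` gives 17700 nM. Compound 3 thus sits in the middle of the three, a gap within the scatter to compound 1 and a modest gap to compound 2. Compound 4 `CCCCCc1ccc(-c2cn(C/C=C3\OC(=O)C(OCc4ccccc4)=C3OCc3ccccc3)nn2)cc1` differs from compound 3 by 4-pentylphenyl in place of 3,5-difluorophenyl on an aromatic carbon. Within the data shown here, two measured steps bear on this change: a 3.2-fold lower number from compound 1 to compound 2 (0.51 log units; beyond the scatter), and a 2.4-fold higher number from compound 2 to compound 3 (0.37 log units; beyond the scatter). Both show that a 4-methylphenyl group on the core goes with a lower number than either halogenated phenyl group. Compound 4 also carries an alkyl chain on the phenyl ring, but a pentyl chain rather than a methyl, for which there is no measured comparison. A step of about the size seen for compound 2 is therefore expected, a 2.7-fold lower number from compound 3 to compound 4 (0.44 log units; beyond the scatter), with wide uncertainty. Compound 4 is estimated to give 6500 nM in this assay, with a likely range from 2000 nM to 25000 nM.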

Compound 4, half-maximal inhibitory concentration: > 100000 nM
Compound 4 gave a limit, no number (the forecaster's own chance of this, stated with the estimate: 5%); middle value at least 15-fold (1.18 log units) away from the limit.
By their numbers in this assay, from the lowest: compound 2; then compounds 3 and 1 (each within the scatter of the next). At a limit, above all of these: compound 4.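

In this assay compound 4 stands at a limit of the assay and not at a number: the limit of > 100000 nM in this assay, at which 1 of the 4 values shown sits. An alkyl chain on this phenyl ring therefore does not by itself go with a lower number, since going from methyl to pentyl gives an at least 13-fold higher number from compound 2 to compound 4 (1.12 log units; beyond the scatter). The pentyl chain also compares poorly with both halogenated phenyl groups, with an at least 5.6-fold higher number from compound 3 to compound 4 (0.75 log units; beyond the scatter) and an at least 4.1-fold higher number from compound 1 to compound 4 (0.61 log units; beyond the scatter).

The compounds shown carry only methyl and pentyl as alkyl groups on this ring, so they leave open how an ethyl, propyl or butyl chain would behave and where along that series the number starts to climb. They also leave open whether a pentyl chain ending in an amine or a carboxylic acid would bring the number back within the range of the assay.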